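The source may hold more compounds than are shown below. What is called first, only, known or untested is meant among the compounds shown, and "the series" means these compounds.

Measured so far:
compound 1 `O=C(c1ccc(-c2nc(-c3ccc(Cl)cc3Cl)no2)s1)C(F)(F)F`: 3000 nM
compound 2 `Cc1ccc(-c2noc(-c3ccc(C(=O)C(F)(F)F)s3)n2)cc1`: 860 nM

Among the measured compounds shown here, in an assay on isolated protein for inhibition of protein deacetylase HDAC6 (Homo sapiens) (on this read-out lower numbers stand for stronger inhibition and higher numbers for weaker inhibition), compound 2 holds the lowest of the two numbers; the only step nearby is a 3.5-fold lower number from compound 1 to compound 2 (0.54 log units; beyond the scatter). Compound 3 `O=C(c1ccc(-c2nc(-c3ccc(F)cc3F)no2)s1)C(F)(F)F` differs from compound 2 by 2,4-difluorophenyl in place of 4-methylphenyl on an aromatic carbon. That single step is the only one that bears on this change: 2,4-dichlorophenyl gave the higher number in compound 1, and compound 3 returns to a related 2,4-difluorophenyl. A modest rise is therefore expected, a 1.9-fold higher number from compound 2 to compound 3 (0.27 log units; within the scatter), smaller than the full step back. Compound 3 is estimated at 1600 nM, with a range of 600 nM to 4500 nM.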

Compound 3, half-maximal inhibitory concentration: 580 nM
Compound 3: middle estimate off by 2.8-fold (0.44 log units), on the high side, outside the stated range (below it).
By their numbers in this assay, from the lowest: compounds 3 and 2 (each within the scatter of the next); then compound 1.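

In this assay, 2,4-difluorophenyl in place of 2,4-dichlorophenyl gives a 5.2-fold lower number from compound 1 to compound 3 (0.71 log units; beyond the scatter), so having two halogens on the phenyl does not by itself bring the higher number seen for compound 1. Set against 4-methylphenyl, the same group gives a 1.5-fold lower number from compound 2 to compound 3 (0.17 log units; within the scatter), so this aromatic carbon tolerates both groups without a readable difference. No measurement on hand accounts for either step.

On these data alone, it remains open whether 4-fluorophenyl or 4-chlorophenyl would group with compound 3 or with compound 1. A phenyl carrying an amine or a carboxylic acid at this place is also untested ground in these compounds.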